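The compounds below may be only part of what the source reports. "The series", "measured", "known", "first", "only" and "open" are said of these compounds alone.

Measured so far in an ADME assay on LNCaP cells (Homo sapiens) for inhibition, read by MTT assay, with a stated time of 72 h; on this read-out higher numbers stand for lower toxicity in this test and lower numbers for higher toxicity in this test:

- Compound 1 `CC(=O)NC(c1ccccc1)c1cc(Cl)c2cccnc2c1O`: 740 nM
- Compound 2 `Oc1ccc(CNc2cccc(C(F)(F)F)c2)c2cccnc12`: > 10000 nM (a limit of the assay)

Compound 2 has only a limit in this assay and no number, as the limit of > 10000 nM in this assay, at which 1 of the 2 values shown sits, records. For the measured compounds named here, compound 1 is the only one of the pair with a measured number, 740 nM, and no step that differs in one place connects these two compounds. The next compound is compound 3 `COc1cccc(NCc2ccc(O)c3ncccc23)c1`, which keeps the core of compound 2 and carries methoxy in place of trifluoromethyl on an aromatic carbon, meta to a large group (methoxy in place of trifluoromethyl on an aromatic carbon). Going by the values given here, no measured step shows what such a change does in this assay, so the expectation remains cautious. The expected change is an at least 1.2-fold lower number from compound 2 to compound 3 (0.09 log units; that floor lies within the scatter), a moderate step toward lower numbers, although a result reported again only as a limit is also quite possible. For compound 3 the estimated value is 8000 nM, with an expected range from 2500 nM to 20000 nM.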

Compound 3, half-maximal cytotoxic concentration: 5000 nM
Compound 3: middle estimate off by 1.6-fold (0.20 log units), on the high side; low and high end bracket the measured number.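

In this assay, for the compounds shown here, methoxy in place of trifluoromethyl on this aromatic carbon, meta to a large group, gives the first readable step at this position: an at least 2.0-fold lower number from compound 2 to compound 3 (0.30 log units; that floor lies within the scatter). With this change, the core of compound 2 gains a measured number through compound 3, 5000 nM, so this core now has a value that can anchor later comparisons, and on this read-out a lower number stands for higher toxicity in this test. The step is only a floor and its true size stays unknown because compound 2 has a limit of the assay and not a number: the limit of > 10000 nM in this assay, at which 1 of the 3 values shown sits.

The compounds shown leave open whether a lower number belongs to methoxy in particular or would also appear with another group on this carbon, such as an amine, a carboxylic acid or a longer chain ending in a hydroxyl. Going by these compounds alone, they also leave open how this pair relates to compound 1, since no step that differs in one place connects compound 1 to either of them.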